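Swapping a phenylethyl for an aminohexyl chain

This account rests on a few compounds, and the source may have more. Where it says the series, first, only, none or still open, it means among the compounds named here.

Measured compounds:
- compound 1 `C[C@@H](Nc1c(C(=O)NCc2ccc(F)cc2)nc(Br)c2cccnc12)c1ccccc1`: > 20000 nM
- compound 2 `N[C@H]1CC[C@H](Nc2c(C(=O)NCc3ccc(Oc4ccccc4)cc3)nc(Br)c3cccnc23)CC1`: 4000 nM

Both compounds share one core and were tested in a functional assay on MDA-MB-435 cells (Homo sapiens) for cytotoxicity, read by MTT assay, with a stated time of 72 h; a lower number here means a stronger inhibitor, a higher number a weaker inhibitor. In this assay compound 1 gives only a limit, > 20000 nM, and not a number. Its standing is therefore fixed by the limit of > 20000 nM in this assay, at which 1 of the 2 values shown sits, alone; it cannot be placed above or below any particular value, only at the edge of what the assay reports. In this assay compound 2 gives 4000 nM, a number rather than a limit. Going by the values given here, no step between the two is given, so their values are stated side by side and nothing more.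

Compound 3 `NCCCCCCNc1c(C(=O)NCc2ccc(F)cc2)nc(Br)c2cccnc12` has not yet been tested. It differs from compound 1 in one place: 6-aminohexyl in place of 1-phenylethyl on a nitrogen on an aromatic ring. Among the compounds with values here, with no measured step to lean on, the size of the change in this assay is open. A step of an at least 3.3-fold lower number from compound 1 to compound 3 (0.52 log units; beyond the scatter) is expected, towards stronger inhibition, but the chance of a second limit is real. Compound 3 is estimated at 6000 nM, with a range from 1500 nM to 25000 nM.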

Compound 3, half-maximal inhibitory concentration: 6000 nM
Compound 3: middle estimate and measured number agree at the digits printed, within the range that was stated.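

In this assay, going by these compounds alone, the swap of 1-phenylethyl for 6-aminohexyl on the nitrogen on an aromatic ring gives an at least 3.3-fold lower number from compound 1 to compound 3 (0.52 log units; beyond the scatter) and this is the only step that can be read so far. It shows that this place tolerates a chain with no ring and with a terminal amine, and that such a chain moves the compound from the edge of what the assay reports to an actual number, with the rest of compound 1 unchanged. As far as these compounds go, compound 1 gives only a limit, so the step has a lower bound and its full size stays unknown: the limit of > 20000 nM in this assay, at which 1 of the 3 values shown sits.

The swap removes a phenyl ring and a stereocentre and brings in an amine all at once, and the compounds shown cannot tell these changes apart or say which of them carries the step. Also open, from the compounds shown here alone, is what a plain hexyl chain, a shorter or longer aminoalkyl chain, or a carboxylic acid at the chain end would give at this place on the same core.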